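This account rests on a few compounds, and the source may have more. Where it says the series, first, only, none or still open, it means among the compounds named here.

Two compounds of this series carry measured numbers. Compound 1 `c1ccc2c(-c3cn4ccnc4c(-c4ccc5ncn(C6CCCCC6)c5c4)n3)cccc2c1` gives 19.3% in a functional assay on NCI-H522 cells (Homo sapiens) for inhibition, read by sulforhodamine B assay, with a stated time of 48 h, tested at 10 uM; a lower number here means less inhibition, a higher number more inhibition at the concentration tested (going by the name of the read-out). Compound 2 `c1cn2cc(-c3ccc4c(c3)ncn4C3CCCCC3)nc(-c3ccc4ncn(C5CCCCC5)c4c3)c2n1` carries a second cyclohexyl on an aromatic nitrogen in place of the naphthyl of compound 1. In this assay compound 2 gives 28.5%. These two values lie within the usual scatter of each other, so compound 2 cannot be set apart from compound 1 on these numbers alone. Compound 3 `c1ccc(Cn2cnc3ccc(-c4nc(-c5ccc6c(c5)ncn6C5CCCCC5)cn5ccnc45)cc32)cc1` is not yet measured. It differs from compound 2 in one place: benzyl in place of cyclohexyl on an aromatic nitrogen. Among the compounds with values here, no measured pair shows what this exchange does, so the expected step from compound 2 to compound 3 in this assay is set near zero, a number 0.5 percentage points lower from compound 2 to compound 3 (within the scatter), with no direction beyond the scatter. Compound 3 is therefore expected at 28%, within a range of 10% to 50%.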

Compound 3, a percentage reported as inhibition, at one concentration (the size of the read-out at that concentration, not a potency): -35.2%
Compound 3: the middle estimate sits 63.2 percentage points above what was measured; measured number outside the range, below it.
By their numbers in this assay, from the lowest: compound 3; then compounds 1 and 2 (each within the scatter of the next).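

In this assay, within the data shown here, benzyl in place of cyclohexyl on an aromatic nitrogen of the five-membered ring gives a number 63.7 percentage points lower from compound 2 to compound 3 (beyond the scatter), the first step at this position, and it shows that the group here has a large bearing on the read-out, with compound 3 at -35.2%, a reading below zero. The exchange swaps a non-aromatic carbon ring for an aromatic one and adds one carbon, and this single step cannot separate those two differences. Nothing in hand explains the size of the step.

As far as these compounds go, it remains open whether a phenyl group, with the aromatic ring held on the nitrogen without the benzyl carbon, would follow benzyl or cyclohexyl at this position. From the compounds shown here alone, a longer chain ending in an amine or a carboxylic acid is equally open.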